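Removing the fluoro: from compound 1 to compound 4

The source may hold more compounds than are shown below. What is called first, only, known or untested is meant among the compounds shown, and "the series" means these compounds.

Compound 1 `N#CC1=C(N)OC(c2c[nH]c3ccccc23)=C(C#N)C1c1ccccc1F` was reported as "not active" (no number reported) in a functional assay, tested at 100 ug/mL (on this read-out higher numbers stand for a stronger effect at the one concentration tested and lower numbers for a weaker effect), with no number given, so it has no single value to stand on. Its two neighbours carry the same core with a different aryl group on the saturated ring carbon: compound 2 `N#CC1=C(N)OC(c2c[nH]c3ccccc23)=C(C#N)C1c1ccc(Br)cc1` gives 14.6%, and compound 3 `Cc1ccccc1C1C(C#N)=C(N)OC(c2c[nH]c3ccccc23)=C1C#N` gives 17.2%; the step of a number 2.6 percentage points higher from compound 2 to compound 3 (within the scatter) shows that these two lie within the scatter of each other. Compound 4 `N#CC1=C(N)OC(c2c[nH]c3ccccc23)=C(C#N)C1c1ccccc1` differs from compound 1 by hydrogen in place of fluoro on an aromatic carbon. Among the measured compounds shown here, no measured step removes a fluoro, so the data give little guidance beyond the weak read-outs seen for compounds 2 and 3. Compound 4 is therefore expected to give about 10%, with a range from 0% to 25%, and may again be reported as not active.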

Compound 4, a percentage reported as activity, at one concentration (the size of the read-out at that concentration, not a potency): 19.3%
Compound 4: middle estimate off by 9.3 percentage points, on the low side; low and high end bracket the measured number.
By their numbers in this assay, from the lowest: compounds 2, 3 and 4 (each within the scatter of the next).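

Compound 4 shows that the aryl group on the saturated ring carbon needs no substituent to give a number in this assay: the plain phenyl reads like its neighbours, with a number 2.1 percentage points higher from compound 3 to compound 4 (within the scatter) and a number 4.7 percentage points higher from compound 2 to compound 4 (within the scatter) on this read-out. Compound 1 gives "not active" (no number reported) and compound 4 gives 19.3%, so the change from 2-fluorophenyl to phenyl separates a compound without a number from one with a number, but no size can be read for this step. Nothing measured explains this difference.

Left open is whether an amine or a carboxylic acid on this phenyl ring would lift the read-out clear of the scatter.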